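A few compounds are considered here, and "the series" means these few. Any claim that something is new, unique, unknown or untested is made for them only; others in the source may bear on it.

In an ADME assay on the whole organism (Mus musculus, strain Swiss Webster) for pharmacokinetics, read by LC-MS, at a dose of 50 mg/kg by the oral route (on this read-out higher numbers stand for higher exposure at the dose given and lower numbers for lower exposure), compound 1 `O=C(Nc1ccc(F)c(-c2nc3ncc(-c4ccc(F)c(F)c4)cc3[nH]2)c1)N1CCCC1` gives 12000 ng.h/mL and compound 2 `O=C(Nc1ccc(F)c(-c2nc3ncc(-c4ccc(F)cc4)cc3[nH]2)c1)N1CCCC1` gives 10200 ng.h/mL, so these two values lie within the scatter of each other. Compound 3 `O=C(Nc1ccc(F)c(-c2nc3ncc(-c4cccc(F)c4F)cc3[nH]2)c1)N1CCCC1` keeps the rest of compound 2 and changes one group: 2,3-difluorophenyl in place of 4-fluorophenyl on an aromatic carbon, with 2,3-difluorophenyl in place of 4-fluorophenyl on an aromatic carbon. Within the data shown here, the only measured step that touches this group is a 1.2-fold lower number from compound 1 to compound 2 (0.07 log units; within the scatter), where hydrogen replaces fluoro on an aromatic carbon. With so small a precedent, the expected step, a 1.0-fold lower number from compound 2 to compound 3 (0.01 log units; within the scatter), stays within the scatter. For compound 3 the estimate is 10000 ng.h/mL, with an expected range from 4500 ng.h/mL to 20000 ng.h/mL.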

Compound 3, area under the concentration-time curve: 4750 ng.h/mL
Compound 3: middle estimate off by 2.1-fold (0.32 log units), on the high side; the measured number falls inside the stated range.
By their numbers in this assay, from the lowest: compound 3; then compounds 2 and 1 (each within the scatter of the next).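

At this position on the core, the 4-fluorophenyl and 3,4-difluorophenyl groups had read within the scatter of each other, but the 2,3-difluorophenyl group separates from both in this assay: a 2.1-fold lower number from compound 2 to compound 3 (0.33 log units; beyond the scatter), and a 2.5-fold lower number from compound 1 to compound 3 (0.40 log units; beyond the scatter). The second step keeps the fluorine count and only places the fluorines differently, so placement on this ring can shift exposure modestly. Nothing available explains this shift. Still open, from the compounds shown here alone, is whether 2-fluorophenyl alone would give a similar step. Also open, going by these compounds, is how plain phenyl or a ring carrying an amine would read here.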